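The source may hold more compounds than are shown below. What is called first, only, known or untested is meant among the compounds shown, and "the series" means these compounds.

Measured compounds:
compound 1, `Cn1c(-c2ccc(NC(=O)CSc3nc4cc(Cl)ccc4o3)cc2)nc(-c2ccccc2)c1-c1ccccc1`: 11.9%
compound 2, `Cc1nnc(SCC(=O)Nc2ccc(-c3nc(-c4ccccc4)c(-c4ccccc4)n3C)cc2)s1`: 34.8%

In a functional assay on HT-29 cells (Homo sapiens) for cytotoxicity, read by MTT assay, with a stated time of 24 h, tested at 0.64 ug/mL (on this read-out higher numbers stand for a stronger effect at the one concentration tested and lower numbers for a weaker effect), compound 1 gives 11.9% and compound 2 gives 34.8%. For the measured compounds named here, compound 2 therefore stands highest of the two numbers, with compound 1 as its only neighbour, and the one measured step is a number 22.9 percentage points higher from compound 1 to compound 2 (beyond the scatter). Compound 3, `Cn1c(-c2ccc(NC(=O)CSC3=NCCS3)cc2)nc(-c2ccccc2)c1-c1ccccc1`, has not yet been measured. It differs from compound 2 as follows: a group of 5 heavy atoms (3 carbon, 1 nitrogen, 1 sulfur; one five-membered non-aromatic ring with 2 hetero atoms) in place of a group of 6 heavy atoms (3 carbon, 2 nitrogen, 1 sulfur; one five-membered aromatic ring with 3 hetero atoms), on a sulfur. Going by the values given here, the single measured step concerns an exchange at the same sulfur, but of one aromatic group for another, so it bears only loosely on the move to a non-aromatic ring in compound 3. Among the compounds with values here, no measured step shows what such a change does. Compound 3 is accordingly expected to stay near compound 2, with a step of a number 9.8 percentage points lower from compound 2 to compound 3 (within the scatter) that may be within the scatter or modestly downward. The estimate for compound 3 in this assay is 25%, with a range from 5% to 50%.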

Compound 3, a percentage reported as activity, at one concentration (the size of the read-out at that concentration, not a potency): 16.8%
The estimate for compound 3 lay 8.2 percentage points above the measured number; the measured number falls inside the stated range.
By their numbers in this assay, from the lowest: compounds 1 and 3 (each within the scatter of the next); then compound 2.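

In this assay, putting the non-aromatic five-membered ring in place of the 5-methyl-1,3,4-thiadiazol-2-yl on the sulfur gives a number 18 percentage points lower from compound 2 to compound 3 (beyond the scatter) and shows that this position does not tolerate every small ring equally. Exchanging the 5-chloro-1,3-benzoxazol-2-yl for that same ring gives a number 4.9 percentage points higher from compound 1 to compound 3 (within the scatter) and so leaves these two groups indistinguishable here, whereas the 5-methyl-1,3,4-thiadiazol-2-yl lies beyond the scatter from both. Nothing available explains this difference.

The compounds shown leave open whether the higher number of compound 2 depends on the methyl group of its ring or on the ring itself. They also do not show how an open-chain group on this sulfur, such as an amine or a carboxylic acid on a longer chain, would compare.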